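Swapping Acetyl for 4-Nitrophenyl on a Ring Nitrogen

The source may report more compounds than this note shows. Statements on the series, on what has been measured and on what is new or still open speak of the compounds shown alone.

Three compounds have been measured in a functional assay on the whole organism (strain Wistar) for inhibition, with Rattus norvegicus as the target, read by paw edema, with stated times of 30 min and 60 min, at a dose of 50 mg/kg by the oral route; on this read-out lower numbers stand for less inhibition and higher numbers for more inhibition at the one dose given (going by the name of the read-out):
compound 1 `Cc1ccc(C2=NN(c3ccc([N+](=O)[O-])cc3)C(c3cn(-c4ccccc4)nc3-c3ccc(Cl)c(Cl)c3)C2)cc1` gives 72.5%
compound 2 `Fc1ccc(C2=NN(c3ccccc3)C(c3cn(-c4ccccc4)nc3-c3ccc(Cl)c(Cl)c3)C2)cc1` gives 55.7%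
compound 3 `CC(=O)N1N=C(c2ccc(F)cc2)CC1c1cn(-c2ccccc2)nc1-c1ccc(Cl)c(Cl)c1` gives 59.5%

Compound 3 stands second highest of these three numbers. Its nearest neighbour is compound 2, lower by an amount within the scatter, and its furthest is compound 1, higher by an amount beyond the scatter. Compound 4 `O=[N+]([O-])c1ccc(N2N=C(c3ccc(F)cc3)CC2c2cn(-c3ccccc3)nc2-c2ccc(Cl)c(Cl)c2)cc1` has not yet been measured. It differs from compound 3 in one place: 4-nitrophenyl in place of acetyl on an amine nitrogen in a ring. Among the measured compounds shown here, one measured step concerns this same ring nitrogen, a number 3.8 percentage points higher from compound 2 to compound 3 (within the scatter), and it lies within the scatter, so phenyl and acetyl on that nitrogen gave much the same read-out. For the measured compounds named here, no single step covers 4-nitrophenyl against acetyl or phenyl. Compound 1 carries 4-nitrophenyl on that nitrogen and compound 2 carries phenyl, but the two also differ in a second place, so their values can be set side by side only loosely: compound 1 gives 72.5% and compound 2 gives 55.7%. From this, a modest rise toward the number of compound 1 is expected for compound 4, one that may still fall within the scatter: a number 7.5 percentage points higher from compound 3 to compound 4 (within the scatter). Compound 4 is therefore estimated at 67%, within a range from 55% to 79%.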

Compound 4, a percentage reported as inhibition, in the whole organism at one dose (the size of the read-out at that dose, not a potency): 60.3%
Beside the measured number, compound 4's estimate is 6.7 percentage points above it; measured number inside the range.
By their numbers in this assay, from the lowest: compounds 2, 3 and 4 (each within the scatter of the next); then compound 1.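

In this assay the step of putting 4-nitrophenyl in place of acetyl on the amine nitrogen in the ring is a number 0.8 percentage points higher from compound 3 to compound 4 (within the scatter) and so, with a 4-fluorophenyl group on the shared core, acetyl, phenyl and 4-nitrophenyl on this nitrogen all give numbers within the scatter of one another. Among the compounds shown here, the single added group tells the same story, since nitro in place of hydrogen on an aromatic carbon of the phenyl on that nitrogen is a number 4.6 percentage points higher from compound 2 to compound 4 (within the scatter) and leaves the read-out where it was. The only step here beyond the scatter lies at the other end of the molecule, where fluoro in place of methyl on an aromatic carbon is a number 12.2 percentage points lower from compound 1 to compound 4 (beyond the scatter) and so, among these compounds, the gap to compound 1 belongs to that exchange and not to the ring nitrogen.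

No measurement available here explains this difference between the two places. As far as these compounds go, it remains open whether methyl would go with acetyl or phenyl on the nitrogen as it does with 4-nitrophenyl, and whether a longer chain in place of acetyl, or an amine or a carboxylic acid in place of nitro, would also leave the read-out unchanged.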